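The source may report more compounds than this note shows. Statements on the series, on what has been measured and on what is new or still open speak of the compounds shown alone.

Measured so far:
Compound 1 `CCC(C)(C)Cc1c[nH]c(CCc2ccc(-c3cnccn3)cc2)n1`: 431 nM
Compound 2 `CCC(C)(C)Cc1c[nH]c(CCc2ccc(-c3cnsc3)cc2)n1`: 44 nM

In a functional assay on HEK293 cells for agonist activity at Bombesin receptor subtype-3 (Homo sapiens), read by luminescence and calcium flux, with a stated time of 10 min (on this read-out higher numbers stand for an effect only at larger amounts of compound and lower numbers for an effect already at smaller amounts), compound 2 gives 44 nM, the lowest of the two numbers, and compound 1 gives 431 nM. Among the measured compounds shown here, the only measured step, a 9.8-fold lower number from compound 1 to compound 2 (0.99 log units; beyond the scatter), exchanged one ring for a different ring. Compound 3 `CCC(C)(C)Cc1c[nH]c(CCc2ccc(-c3ccns3)cc2)n1` keeps the same ring as compound 2 and differs only in 1,2-thiazol-5-yl in place of 1,2-thiazol-4-yl on an aromatic carbon. For the measured compounds named here, no measured step concerns moving the point of attachment within the same ring, so the expected change is none beyond the scatter, a 1.4-fold higher number from compound 2 to compound 3 (0.13 log units; within the scatter). The estimate for compound 3 is therefore 60 nM, with a range from 20 nM to 200 nM.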

Compound 3, half-maximal effective concentration: 63 nM
Compound 3: the middle estimate sits 1.1-fold (0.02 log units) below what was measured; the range from low to high includes it.
By their numbers in this assay, from the lowest: compounds 2 and 3 (each within the scatter of the next); then compound 1.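

Joining the ring through a different carbon, 1,2-thiazol-5-yl in place of 1,2-thiazol-4-yl, gives two compounds this read-out cannot tell apart: a 1.4-fold higher number from compound 2 to compound 3 (0.16 log units; within the scatter). The advantage over pyrazin-2-yl is therefore not tied to one attachment, since the second thiazole also shows a 6.8-fold lower number from compound 1 to compound 3 (0.84 log units; beyond the scatter). Nothing available here explains these results. Still open, as far as these compounds go, is how a plain phenyl ring, or a thiazole ring carrying an amine or a carboxylic acid, would read at this place on the shared core.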